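The compounds below may be only part of what the source reports. "The series", "measured", "known", "first", "only" and "open" are said of these compounds alone.

Working notes on the series. Compound 1 `Cc1nn(-c2nc(-c3ccc(Cl)c(Cl)c3)c(SC(C)C)s2)c(C(=O)O)c1-c1ccc(Cl)cc1` is the reference point; in a functional assay on BJAB cells (Homo sapiens) for antiproliferative activity, with a stated time of 4 days (on this read-out lower numbers stand for an effect already at smaller amounts and higher numbers for an effect only at larger amounts of compound), compound 1 gives 2500 nM. Compound 2 `Cc1nn(-c2nc(-c3ccc(Cl)c(Cl)c3)c(SC(C)C)s2)c(C(=O)O)c1-c1cccc(Cl)c1C` gives 5100 nM, a change of a 2.0-fold higher number from compound 1 to compound 2 (0.31 log units; beyond the scatter). Compound 3 `Cc1nn(-c2nc(-c3ccc(Cl)c(Cl)c3)c(SC(C)C)s2)c(C(=O)O)c1-c1ccc(C(F)(F)F)cc1` gives 3500 nM; the step of a 1.4-fold higher number from compound 1 to compound 3 (0.15 log units; within the scatter) and the step of a 1.5-fold lower number from compound 2 to compound 3 (0.16 log units; within the scatter) both stay within the scatter. Among the measured compounds shown here, on the three numbers known, compound 3 sits second highest, closest to compound 1 and furthest from compound 2, with neither gap beyond the scatter.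

Compound 4 `Cc1nn(-c2nc(-c3ccc(Cl)c(Cl)c3)c(SC(C)C)s2)c(C(=O)O)c1-c1cccnc1` carries the change (pyridin-3-yl in place of 4-(trifluoromethyl)phenyl on an aromatic carbon). For the measured compounds named here, all three measured steps vary the same group at this place on the shared core, and the whole spread across them is narrow; only the step to compound 2 exceeds the scatter, and only modestly. Going by the values given here, the change to compound 4 introduces a ring nitrogen not seen in the measured set, so no measured step directly covers it. The expected step for this assay is a 1.1-fold lower number from compound 3 to compound 4 (0.04 log units; within the scatter), no clear direction, and within the scatter. The estimate for compound 4 is 3200 nM, with a range of 1200 nM to 9000 nM.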

Compound 4, half-maximal effective concentration: 12000 nM
Compound 4: middle estimate off by 3.8-fold (0.57 log units), on the low side; the measured number lies above the stated range.
By their numbers in this assay, from the lowest: compounds 1, 3 and 2 (each within the scatter of the next, the first and the last beyond it); then compound 4.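

At this place, the aromatic carbon next to the ring atom that bears a carboxy group, the three carbon-only aromatic rings lie within a narrow spread in this assay, but pyridin-3-yl falls clearly outside it: a 3.4-fold higher number from compound 3 to compound 4 (0.54 log units; beyond the scatter), a 2.4-fold higher number from compound 2 to compound 4 (0.37 log units; beyond the scatter) and a 4.8-fold higher number from compound 1 to compound 4 (0.68 log units; beyond the scatter). The position therefore does respond to the choice of ring, and compound 4 is the only compound shown with a ring nitrogen and a hydrogen-bond acceptor in this group, and the only one without a further substituent on the ring. No measurement bears on the reason for this step.

Open, on these data alone, is whether the ring nitrogen or the missing substituent accounts for the step. A plain phenyl group, or a pyridin-3-yl ring carrying a chloro or trifluoromethyl group, would separate the two.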